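Chloro for Trifluoromethyl on the Phenoxy Ring

The compounds below may be only part of what the source reports. "The series", "measured", "known", "first", "only" and "open" are said of these compounds alone.

Compound 1 `CC(CCNC(=O)c1c(Cl)cncc1Cl)N1CCC(C(Oc2cccc(C(F)(F)F)c2)c2ccc(C(F)(F)F)cc2)CC1`: 7000 nM
Compound 2 `CCO/N=C(/c1ccc(Br)cc1)C1CCN(C(CC)CCNC(=O)c2c(C)cc[n+]([O-])c2C)CC1`: > 177000 nM, a limit of the assay
Compound 3 `CCO/N=C(/c1ccc(Br)cc1)C1CCN(CCCNC(=O)c2c(C)cc[n+]([O-])c2C)CC1`: 7500 nM

In an ADME assay on PBMC cells (Homo sapiens) for cytotoxicity (a lower number here means that less compound is tolerated, a higher number that more compound is tolerated), compound 1 gives 7000 nM, the lowest of the two numbers measured, though the gap to compound 3 at 7500 nM lies within the scatter. For compound 2 the result is only a limit, > 177000 nM, and not a number (the limit of > 177000 nM in this assay, at which 1 of the 3 values shown sits). For the measured compounds named here, the single step measured in this set, an at least 23-fold lower number from compound 2 to compound 3 (1.37 log units; beyond the scatter), concerns a hydrogen in place of an ethyl on the chain and says nothing about the aromatic rings.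

Compound 4 `CC(CCNC(=O)c1c(Cl)cncc1Cl)N1CCC(C(Oc2cccc(Cl)c2)c2ccc(C(F)(F)F)cc2)CC1` is compound 1 with chloro in place of trifluoromethyl on an aromatic carbon, so that the 3-(trifluoromethyl)phenoxy becomes 3-chlorophenoxy. Going by the values given here, no measured step bears on this change, so no step beyond the scatter is expected in this assay in either direction. Compound 4 is therefore expected to give about 7000 nM, estimated between 3000 nM and 16000 nM. The expected step is no change at the digits printed from compound 1 to compound 4 (within the scatter).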

Compound 4, half-maximal cytotoxic concentration: 8100 nM
Estimate against measurement, compound 4: 1.2-fold (0.06 log units) below; the measured number falls inside the stated range.
By their numbers in this assay, from the lowest: compounds 1, 3 and 4 (each within the scatter of the next). At a limit, above all of these: compound 2.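

For the compounds shown here, with a 1.2-fold higher number from compound 1 to compound 4 (0.06 log units; within the scatter) in this assay, the set gains its first measured step on an aromatic ring; the only earlier step lay on the chain. It shows that on this phenoxy ring, chloro can stand in place of trifluoromethyl, one heavy atom for four, and compound 4 cannot be told apart from compound 1 in this read-out. Nothing measured here offers a reason for this result.

From the compounds shown here alone, whether the same holds for other groups at this place on the phenoxy ring, such as a nitrile, a methoxy or an amine, remains open. Also open, going by these compounds, is whether chloro would behave alike in place of the trifluoromethyl on the other aromatic ring of compound 1.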